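The source may report more compounds than this note shows. Statements on the series, on what has been measured and on what is new or still open speak of the compounds shown alone.

Measured compounds so far:
- compound 1, `Nc1nc(Cl)c2ncn(Cc3ccccc3CCl)c2n1`: 2460 nM
- compound 2, `Nc1nc(Cl)c2ncn(Cc3ccc(CCl)cc3)c2n1`: 15500 nM
- compound 3, `ClCc1ccccc1Cn1cnc2ncnc(Cl)c21`: 4890 nM

All three numbers come from a functional assay on OVCAR-4 cells (Homo sapiens) for cytotoxicity, read by sulforhodamine B assay, with a stated time of 48 h; on this read-out lower numbers stand for stronger inhibition of growth and higher numbers for weaker inhibition of growth. Compound 1 stands lowest of the three. Compound 3 gives 4890 nM, a number within the scatter of compound 1, so these two cannot be ordered. Compound 2 gives 15500 nM, which is beyond the scatter and the furthest from compound 1 among the numbers shown.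

Compound 4 is `ClCc1ccccc1Cn1cnc2c(Cl)nc(Cl)nc21`. Against compound 1 the change is chloro in place of amino on an aromatic carbon. Going by the values given here, no pair of measured compounds differs in this one place, so no measured step tells the size of this change; the numbers for compound 1 and compound 3 only show that a close analogue on the same core can land within the scatter of compound 1.

On that basis the step of a 1.2-fold higher number from compound 1 to compound 4 (0.09 log units; within the scatter) is expected to be small, with no direction beyond the scatter. Compound 4 is estimated at 3000 nM, in the range 1000 nM to 9000 nM.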

Compound 4, concentration for 50% growth inhibition: 1770 nM
Beside the measured number, compound 4's estimate is 1.7-fold (0.23 log units) above it; measured number inside the range.
By their numbers in this assay, from the lowest: compounds 4, 1 and 3 (each within the scatter of the next, the first and the last beyond it); then compound 2.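

In this assay, the first step read at this position, a 1.4-fold lower number from compound 1 to compound 4 (0.14 log units; within the scatter), lies within the scatter, so the two compounds cannot be ordered. On this one pair, the amino group on the aromatic carbon between two ring nitrogen atoms can give way to chloro with no change that this read-out resolves. No measurement to hand bears on why the two compounds read alike.

Going by these compounds, whether a hydrogen, a methyl, a methoxy or a dimethylamino group on the same carbon would give a step beyond the scatter stays open. Also open, on these data alone, is whether chloro in place of amino gives a step of similar size on the core of compound 2, which stands beyond the scatter of compound 1.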